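Replacing the oxadiazole of compound 2 with a pyrazole

The source may hold more compounds than are shown below. What is called first, only, known or untested is meant among the compounds shown, and "the series" means these compounds.

Measured so far in an in vitro ADME assay on microsomes from liver (Homo sapiens) for pharmacokinetics (on this read-out higher numbers stand for fast clearance and lower numbers for slow clearance), as follows
- compound 1 `COc1ccc(OCC(=O)N2CCC3(CC2)CN(Cc2ccc(OCC(C)C)cc2Cl)C3)cc1` gives 88 mL.min-1.g-1 as a number
- compound 2 `COc1ccc(OCC(=O)N2CCC3(CC2)CN(Cc2ccc(-c4nnc(C)o4)cc2)C3)cc1` gives < 8 mL.min-1.g-1 as a limit

For compound 2 the reading is the limit of < 8 mL.min-1.g-1 in this assay, at which 1 of the 2 values shown sits, and is not a number. Within the data shown here, compound 1 reads 88 mL.min-1.g-1 on the same scale, and no step between measured compounds differing in one place is available.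

Compound 3 `COc1ccc(OCC(=O)N2CCC3(CC2)CN(Cc2ccc(-n4cccn4)cc2)C3)cc1` keeps the shared core of compound 2 and changes one group: 1H-pyrazol-1-yl in place of 5-methyl-1,3,4-oxadiazol-2-yl on an aromatic carbon, with 1H-pyrazol-1-yl in place of 5-methyl-1,3,4-oxadiazol-2-yl on an aromatic carbon, para to a large group.

The expectation starts from compound 2, whose < 8 mL.min-1.g-1 is a limit of the assay. The expected step of an at least 1.7-fold higher number from compound 2 to compound 3 (0.24 log units; that floor lies within the scatter) is a modest rise in this assay, possibly none beyond the scatter. For compound 3 the estimated value is 14 mL.min-1.g-1, with 7 mL.min-1.g-1 to 35 mL.min-1.g-1 as the expected range.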

Compound 3, intrinsic clearance in microsomes: 20 mL.min-1.g-1
For compound 3 the middle estimate is 1.4-fold (0.15 log units) below the measured one; the measured number falls inside the stated range.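

In this assay, exchanging 5-methyl-1,3,4-oxadiazol-2-yl for 1H-pyrazol-1-yl on this aromatic carbon, para to a large group, gives an at least 2.5-fold higher number from compound 2 to compound 3 (0.39 log units; beyond the scatter), so the read-out at this position depends on which five-membered aromatic ring is attached. From the compounds shown here alone, the full size of the step stays unknown, since the reading of compound 2 is a limit and not a number: the limit of < 8 mL.min-1.g-1 in this assay, at which 1 of the 3 values shown sits. Compound 3 gives 20 mL.min-1.g-1, which places a true number on the scale for this position, so that further changes here can be read as steps in either direction.

The exchange removes the methyl group and alters the ring at the same time, and the compounds shown do not separate these two changes. Going by these compounds, how an unsubstituted 1,3,4-oxadiazol-2-yl, a methyl-bearing pyrazole or a nitrile on this aromatic carbon would read in this assay remains open.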